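The source may report more compounds than this note shows. Statements on the series, on what has been measured and on what is new or still open speak of the compounds shown alone.

Compound 3 `Cc1cc(C)cc(NC(=O)NCCNS(=O)(=O)c2ccc(-c3ccccc3OCc3ccccc3)s2)c1` was tested in a functional assay on RS4-11 cells (Homo sapiens) for inhibition, read by CCK-8 assay, with a stated time of 48 h; a lower number here means a stronger inhibitor, a higher number a weaker inhibitor. In this assay compound 3 gives only a limit of the assay, > 50000 nM. Its two close relatives stand at the same place. Compound 1 `O=S(=O)(NCCNC(=S)Nc1cccc(Cl)c1)c1ccc(-c2ccccc2OCc2ccccc2)s1` reaches only a limit in this assay, namely > 50000 nM. Compound 2 `O=S(=O)(NCCNC(=S)Nc1ccc(Cl)cc1)c1ccc(-c2ccccc2OCc2ccccc2)s1` likewise reaches only a limit in this assay, namely > 50000 nM. Because all three values sit on (the limit of > 50000 nM in this assay, at which 3 of the 3 values shown sit), none of the steps between them can be sized: a step that the two limits leave unreadable from compound 1 to compound 2, a step that the two limits leave unreadable from compound 1 to compound 3 and a step that the two limits leave unreadable from compound 2 to compound 3. Compound 4 `O=C(NCCNS(=O)(=O)c1ccc(-c2ccccc2OCc2ccccc2)s1)Nc1cc(Cl)cc(Cl)c1` differs from compound 3 in a single place: 3,5-dichlorophenyl in place of 3,5-dimethylphenyl on an amide-type nitrogen. Among the measured compounds shown here, none of the measured steps touches this part of the molecule, so the measured series gives neither a direction nor a size for the change. With every value in the series resting on a limit, the step from compound 3 is expected to be a step that the limit leaves unreadable from compound 3 to compound 4, and the assay would most likely report a limit once more. Compound 4 is therefore expected to give 60000 nM in this assay, within a range from 15000 nM to 200000 nM.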

Compound 4, half-maximal inhibitory concentration: > 20000 nM
Compound 4: no number, only a limit; the forecaster's own chance of this, stated with the estimate: 80%; the middle value is on the limit's open side.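

Compound 4 also reaches only a limit of the assay, > 20000 nM. Among the compounds shown here, no step from compound 1, compound 2 or compound 3 to compound 4 can be read. The compounds shown leave open whether any group on the amide-type nitrogen would give a measurable value in this assay.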